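Swapping the Lactam Ring for an Acetylated Pyrrolidine

The source may hold more compounds than are shown below. What is called first, only, known or untested is meant among the compounds shown, and "the series" means these compounds.

Compound 1 `Cn1ccc2ccc(-c3cc(Nc4ccccc4S(=O)(=O)N4CCOCC4)cc4nccnc34)cc21` is measured in an ADME assay on microsomes from liver (Mus musculus, strain CD-1) for metabolic stability, read by LC-MS, tested at 2 uM (a higher number here means that the compound lasts longer, a lower number that the compound disappears faster), and gives 0.367 h. Compound 2 `Cn1ccc2ccc(-c3cc(Nc4cnccc4C(=O)NC4CCNC(=O)C4)cc4nccnc34)cc21` gives > 1 h in this assay, which is a limit of the measurement rather than a number; it therefore sits at the limit of > 1 h in this assay, at which 1 of the 2 values shown sits. Compound 3 `CC(=O)N1CCC(NC(=O)c2ccncc2Nc2cc(-c3ccc4ccn(C)c4c3)c3nccnc3c2)C1` carries 1-acetylpyrrolidin-3-yl in place of 2-oxopiperidin-4-yl on an amide-type nitrogen. Among the measured compounds shown here, no measured pair shows this change, so only an expectation is possible. The step is expected to be small, within the usual scatter: a step that the limit leaves unreadable from compound 2 to compound 3. The estimate for compound 3 in this assay is 1.2 h, with a range from 0.4 h to 3 h.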

Compound 3, half-life: 0.667 h
The estimate for compound 3 lay 1.8-fold (0.26 log units) above the measured number; the range from low to high includes it.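

Among the compounds shown here, this is the first reading of a change on this amide-type nitrogen: in this assay, putting 1-acetylpyrrolidin-3-yl in place of 2-oxopiperidin-4-yl gives an at least 1.4-fold lower number from compound 2 to compound 3 (0.17 log units; that floor lies within the scatter). The full size of the step cannot be read, because compound 2 carries a limit rather than a number: the limit of > 1 h in this assay, at which 1 of the 3 values shown sits.

Open, going by these compounds, is whether the ring size or the acetyl group goes with this step. A 1-acetylpiperidin-4-yl group, or a pyrrolidin-3-yl group with a free amine, would pull those two apart.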